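Fluoro on the pyrimidinone core of a dioxolane nucleoside

The source may report more compounds than this note shows. Statements on the series, on what has been measured and on what is new or still open speak of the compounds shown alone.

Three compounds share one core in an ADME assay on HepG2 2.2.15 cells (Homo sapiens) for cytotoxicity, read by neutral red uptake; on this read-out higher numbers stand for lower toxicity in this test and lower numbers for higher toxicity in this test. Compound 1 `O=c1n(C2CSC(CO)O2)ccc2nc(-c3ccc([N+](=O)[O-])cc3)cn12` carries a sulfur-containing five-membered ring, and in this assay compound 1 reaches only a limit, > 26700 nM, not a number. Compound 2 `O=c1n([C@H]2CO[C@H](CO)O2)ccc2nc(-c3ccc([N+](=O)[O-])cc3)cn12` and compound 3 `O=c1n([C@H]2CO[C@@H](CO)O2)ccc2nc(-c3ccc([N+](=O)[O-])cc3)cn12` have the same atoms and bonds and differ only in configuration as drawn; in this assay compound 2 gives 517000 nM and compound 3 gives 486000 nM. The step of a 1.1-fold lower number from compound 2 to compound 3 (0.03 log units; within the scatter) shows that the two numbers sit within the scatter of each other, so compound 3 stands level with compound 2, and the third value shown is a limit. The steps a step that the limit leaves unreadable from compound 1 to compound 2 and a step that the limit leaves unreadable from compound 1 to compound 3 cannot be sized because of the limit of > 26700 nM in this assay, at which 1 of the 3 values shown sits.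

Compound 4 `O=c1n([C@H]2CO[C@@H](CO)O2)cc(F)c2nc(-c3ccc([N+](=O)[O-])cc3)cn12` differs from compound 3 by fluoro in place of hydrogen on an aromatic carbon. No measured step touches this position on the core, so nothing among the shown steps bears on the change, and none of the readable steps exceeds the scatter. He therefore expects a step of a 1.1-fold lower number from compound 3 to compound 4 (0.03 log units; within the scatter), none beyond the scatter. For compound 4 in this assay he estimates 450000 nM, within a range from 200000 nM to 1000000 nM.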

Compound 4, half-maximal cytotoxic concentration: 1390000 nM
The estimate for compound 4 lay 3.1-fold (0.49 log units) below the measured number; measured number above the stated range.
By their numbers in this assay, from the lowest: compounds 3 and 2 (each within the scatter of the next); then compound 4.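

In this assay, fluoro in place of hydrogen on this aromatic carbon, part of a six-membered aromatic ring with 2 nitrogen, gives a 2.9-fold higher number from compound 3 to compound 4 (0.46 log units; beyond the scatter) and is the first readable step among these compounds to pass the scatter, though it remains modest. Among these compounds, the only earlier readable step, a change of configuration at a saturated ring carbon, gives a 1.1-fold lower number from compound 2 to compound 3 (0.03 log units; within the scatter), so this single added fluorine atom on the shared core moves the number where that change did not, and here the move is towards lower toxicity in this test. Nothing shown here bears on why this replacement raises the number.

The compounds shown leave open whether chloro, a methyl group or an amine on this same aromatic carbon would raise the number as fluoro does, leave it level with compound 3, or lower it. They also leave open whether fluoro would give a step of similar size in the configuration of compound 2 or with the sulfur-containing five-membered ring of compound 1.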